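The source may report more compounds than this note shows. Statements on the series, on what has been measured and on what is new or still open speak of the compounds shown alone.

Compound 1, `CCCCn1ccc(N2CCC(c3ccccc3)CC2)c(C#N)c1=O`: 309%
Compound 2, `N#Cc1c(N2CCC(c3cccc(F)c3)CC2)ccn(CC2CC2)c1=O`: 268%
Compound 3, `N#Cc1c(N2CCC(c3cccc(C(F)(F)F)c3)CC2)ccn(CC2CC2)c1=O`: 191%

In a functional assay on CHO cells for positive allosteric modulation of metabotropic glutamate receptor 2 (Homo sapiens), with a stated time of 30 min (on this read-out higher numbers stand for larger maximal responses and lower numbers for smaller maximal responses), compound 2 stands second highest of these three numbers. Its nearest neighbour is compound 1, whose response is higher by more than the scatter, and the furthest is compound 3, whose response is lower by more than the scatter.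

Compound 4, `N#Cc1c(N2CCC(c3cc(F)cc(F)c3)CC2)ccn(CC2CC2)c1=O`, differs from compound 2 by fluoro in place of hydrogen on an aromatic carbon. The new fluoro sits on the same six-membered aromatic ring of carbon only, meta to the fluoro group already present.

Going by the values given here, only one measured step touches that ring: a number 77 percentage points lower from compound 2 to compound 3 (beyond the scatter). Among the compounds with values here, that step swapped a group rather than adding one, so it bears on compound 4 only loosely; no measured pair adds a second fluoro to this ring. Adding a small group on this ring is therefore expected to cost some response, but less than the change to trifluoromethyl did. For compound 4 the expected step is a number 33 percentage points lower from compound 2 to compound 4 (beyond the scatter). Compound 4 is thus estimated at 235%, within a range from 185% to 285%.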

Compound 4, largest response reached (Emax), in percent of the reference or control that the assay uses: 234%
For compound 4 the middle estimate is 1 percentage points above the measured one, within the range that was stated.
By their numbers in this assay, from the lowest: compound 3; then compound 4; then compound 2; then compound 1.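

In this assay, adding a second fluoro to the ring, which turns the 3-fluorophenyl group into the 3,5-difluorophenyl group, gives a number 34 percentage points lower from compound 2 to compound 4 (beyond the scatter). Going by these compounds alone, until now the only measured change on this ring was a swap of one group for another, a number 77 percentage points lower from compound 2 to compound 3 (beyond the scatter), whereas this step shows that adding a single fluoro atom on a ring carbon that carried only hydrogen also lowers the maximal response by more than the scatter. Nothing measured here explains why this added fluoro lowers the response.

The compounds shown leave open whether a chloro, methyl or methoxy group on the same ring carbon would lower the response as much. Also open, on these data alone, is how a phenyl ring with no fluoro at all would behave alongside the cyclopropylmethyl group.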